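Swapping the Chain-End Nitrile for a Triazole

The compounds below may be only part of what the source reports. "The series", "measured", "known", "first", "only" and "open" are said of these compounds alone.

Compound 1 `CCc1cc(C(C)=O)c(O)cc1OCCCCC#N` stands highest of the three measured compounds in an assay on isolated protein for binding affinity to leukotriene B4 receptor 1 (Homo sapiens), tested at 1 uM (a higher number here means more inhibition at the concentration tested (going by the name of the read-out), a lower number less inhibition), where compound 1 gives 57%. Compound 2 `CCCCc1cc(C(C)=O)c(O)cc1OCCCCC#N` gives 13%, and compound 3 `CC(=O)c1cc(CC2CO2)c(OCCCCC#N)cc1O` gives 24%. Both measured steps away from compound 1 lower the read-out: a number 44 percentage points lower from compound 1 to compound 2 (beyond the scatter), and a number 33 percentage points lower from compound 1 to compound 3 (beyond the scatter); between those two, a number 11 percentage points higher from compound 2 to compound 3 (beyond the scatter). All three steps concern groups attached directly to the shared core. Compound 4 `CCc1cc(C(C)=O)c(O)cc1OCCCCCn1cncn1` instead alters the far end of the chain: (1H-1,2,4-triazol-1-yl)methyl in place of cyano on a saturated chain carbon, four bonds along the chain from an oxygen on an aromatic ring. Among the compounds with values here, no measured step touches this part of the structure, so the measured steps give no direct guide; what they do show is that every change made so far away from compound 1 has lowered the number. A modest loss with wide uncertainty is therefore the expectation, and the expected step is a number 12 percentage points lower from compound 1 to compound 4 (beyond the scatter). Compound 4 is thus estimated to give about 45%, expected to lie between 15% and 75%.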

Compound 4, a percentage reported as inhibition, at one concentration (the size of the read-out at that concentration, not a potency): 30%
Estimate against measurement, compound 4: 15 percentage points above; the range from low to high includes it.
By their numbers in this assay, from the lowest: compound 2; then compounds 3 and 4 (each within the scatter of the next); then compound 1.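

The far end of the chain, four bonds along the chain from an oxygen on an aromatic ring, proves to matter in this assay: putting (1H-1,2,4-triazol-1-yl)methyl in place of cyano gives a number 27 percentage points lower from compound 1 to compound 4 (beyond the scatter) and so extends the sensitivity seen for groups on the shared core to this end of the molecule. The change does not remove the read-out, since compound 4 gives 30% even with the larger ring group in place of the nitrile. No available evidence accounts for this step.

The compounds shown leave open whether a carboxylic acid or an amine at the chain end would keep the read-out closer to that of compound 1. They also leave open whether a shorter chain carrying the triazole would do so.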